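This account rests on a few compounds, and the source may have more. Where it says the series, first, only, none or still open, it means among the compounds named here.

Measured so far in a functional assay on HeLa cells (Homo sapiens) for inhibition, read by MTT assay, with a stated time of 72 h; a higher number here means a weaker inhibitor, a lower number a stronger inhibitor

compound 1 `COc1cc(OC)c(-c2cc(=O)c3ccc(O)cc3o2)cc1OC` gives > 150000 nM as a limit
compound 2 `COc1cc(OC)c(OC)cc1/C=C/C(=O)c1ccccc1` gives > 150000 nM as a limit

Compound 2 stands at > 150000 nM as a limit and has no number of its own. Going by the values given here, the series so far offers only the limit of > 150000 nM in this assay, at which 2 of the 2 values shown sit, and no measured step between compounds.

Compound 3 `COc1cc(OC)c(OC)cc1/C=C/C(=O)c1ccc(F)cc1` differs from compound 2 in one place: fluoro in place of hydrogen on an aromatic carbon in words, fluoro in place of hydrogen on an aromatic carbon, para to a large group, turning phenyl into 4-fluorophenyl.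

Among the compounds with values here, with no measured step to draw on, the expectation in this assay is weak inhibition again, with no shift clearly beyond the scatter. The estimated size of an at least 1.5-fold lower number from compound 2 to compound 3 (0.17 log units; that floor lies within the scatter) is small and is reckoned against a limit, not a number. For compound 3 the estimated value is 100000 nM with an expected range from 25000 nM to 200000 nM and a limit in place of a number remains quite possible.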

Compound 3, half-maximal inhibitory concentration: 28600 nM
Compound 3: the middle estimate sits 3.5-fold (0.54 log units) above what was measured, and the stated range covers the measured number.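

In this assay, fluoro in place of hydrogen on an aromatic carbon, para to a large group, gives an at least 5.2-fold lower number from compound 2 to compound 3 (0.71 log units; beyond the scatter). The change of a single heavy atom, turning phenyl into 4-fluorophenyl, is thus enough to take this series from a limit to a measured number, and this position is the first shown to respond. The step can be read only as a minimum because its starting value is a limit and not a number: the limit of > 150000 nM in this assay, at which 2 of the 3 values shown sit.

As far as these compounds go, whether this response is specific to fluoro stays open, since chloro, methoxy or an amine on the same carbon would separate it from other replacements of hydrogen. Also open, from the compounds shown here alone, is whether the same replacement would take the core of compound 1 off its limit.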